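Hydrogen in place of hydroxy on compound 1

The compounds below may be only part of what the source reports. "The series", "measured", "known", "first", "only" and "open" are said of these compounds alone.

Values measured so far in a functional assay on CCRF-CEM cells (Homo sapiens) for antiproliferative activity, read by fluorescence and resazurin assay, with a stated time of 48 h; on this read-out lower numbers stand for stronger inhibition and higher numbers for weaker inhibition
- compound 1 `CCOc1ccc(NC(=O)c2cc3ccc(O)cc3oc2=O)cc1` gives 12600 nM
- compound 2 `Cc1noc(NS(=O)(=O)c2ccc(NC(=O)c3cc4cc(Br)ccc4oc3=O)cc2)c1C` gives 14600 nM

Compound 1 and compound 2 lie within the scatter of each other, so neither can be placed ahead of the other on these two numbers. Compound 3 `CCOc1ccc(NC(=O)c2cc3ccccc3oc2=O)cc1` is still unmeasured. It has hydrogen in place of hydroxy on an aromatic carbon of the core of compound 1, on a six-membered aromatic ring of carbon only, part of a fused or bridged system of two rings. For the measured compounds named here, no pair of measured compounds differs in one place only, so the series offers no direct guide to the size of this change. The expectation therefore starts from compound 1 at 12600 nM and adds only a small allowance. The estimated step of a 1.2-fold higher number from compound 1 to compound 3 (0.08 log units; within the scatter) is expected to stay within the scatter in this assay with no firm direction. Compound 3 is estimated at 15000 nM with an expected range of 6000 nM to 40000 nM on the same read-out.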

Compound 3, half-maximal inhibitory concentration: 17900 nM
Compound 3: middle estimate off by 1.2-fold (0.08 log units), on the low side; measured number inside the range.
By their numbers in this assay, from the lowest: compounds 1, 2 and 3 (each within the scatter of the next).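

In this assay, for the compounds shown here, the hydroxy on the aromatic carbon of the core of compound 1 and the hydrogen that takes its place give a step of a 1.4-fold higher number from compound 1 to compound 3 (0.15 log units; within the scatter), the first comparison of two compounds that differ in one place only. This step lies within the scatter, so the two compounds cannot be told apart on this read-out, and the hydroxy at this position, meta to a fused ring and para to a fused ring, is not shown to be required for the antiproliferative activity measured here. No measured information on these compounds accounts for this result, and the comparison gives no basis for assigning a role to the hydroxy.

Going by these compounds, this single exchange covers only hydroxy and hydrogen at this position, so it remains open whether a methoxy group, an amine or a fluorine atom on the same aromatic carbon would give a number beyond the scatter. On these data alone, it also remains open whether the same exchange would give a similar step on a compound that differs elsewhere from compound 1.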